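A few compounds are considered here, and "the series" means these few. Any claim that something is new, unique, unknown or untested is made for them only; others in the source may bear on it.

Working notes on the series. For the measured compounds named here, in a toxicity assay on HEK-293T cells (Homo sapiens) for cytotoxicity, read by MTT assay, with a stated time of 48 h (a higher number here means a weaker inhibitor, a lower number a stronger inhibitor), compound 1 (`C=C1[C@H](OCC(C)C)[C@@H](OC(C)=O)[C@@H](OC(C)=O)C(C)(C)[C@@H]2O[C@H]2[C@H](C)[C@H](OC(=O)c2ccccc2)[C@@]2(O)C[C@@](C)(OC(C)=O)[C@H](OC(C)=O)[C@@H]2[C@H]1OCC(C)C`) gives 48100 nM as the only true number so far. Compound 2 (`CC(=O)O[C@@H]1[C@@H]2[C@@H](OCC(C)C)C3(CO3)[C@H](O)[C@@H](O)[C@@H](O)C(C)(C)/C=C/[C@H](C)[C@H](OC(=O)c3ccccc3)[C@@]2(O)C[C@@]1(C)O`) reads > 100000 nM and this is a limit of the assay, not a number. Compound 3 (`C=C1[C@H](OC(C)=O)[C@@H](OC(C)=O)[C@@H](O)C(C)(C)/C=C/[C@H](C)[C@H](OC(=O)c2ccccc2)[C@@]2(O)C[C@@](C)(O)[C@H](OC(C)=O)[C@@H]2[C@H]1OCC(C)C`) reads > 100000 nM and this too is a limit, not a number. Taken together, the series shows the limit of > 100000 nM in this assay, at which 2 of the 3 values shown sit, as its most common reading, and compound 3 stands there with no measured position of its own.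

The next entry is compound 4 (`C=C1[C@H](OC(C)=O)[C@@H](OC(C)=O)[C@@H](OC(C)=O)C(C)(C)/C=C/[C@H](C)[C@H](OC(=O)c2ccccc2)[C@@]2(O)C[C@@](C)(O)[C@H](OC(C)=O)[C@@H]2[C@H]1OCC(C)C`), which differs from compound 3 by one change: acetyl in place of hydrogen on an oxygen on a saturated carbon (hydroxy to acetoxy). Going by the values given here, no measured pair isolates this change, so any expectation rests on thin ground. Compound 1 also has acetoxy in that place and differs from compound 4 elsewhere too. As the nearest guide, compound 1 sits at 48100 nM in this assay. A small move toward stronger inhibition is expected, perhaps none beyond the scatter, and a reading at the limit remains quite possible. The expected change is an at least 1.2-fold lower number from compound 3 to compound 4 (0.09 log units; that floor lies within the scatter) on this estimate. Compound 4 is expected at 80000 nM in this assay with an estimated range from 30000 nM to 150000 nM around that figure.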

Compound 4, half-maximal inhibitory concentration: 39300 nM
Estimate against measurement, compound 4: 2.0-fold (0.31 log units) above; the measured number falls inside the stated range.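

Acetoxy in place of hydroxy now has a measured pair of its own, the first in the series to isolate a single change: on this oxygen on a saturated carbon, this assay gives an at least 2.5-fold lower number from compound 3 to compound 4 (0.40 log units; beyond the scatter). Compound 3 reads > 100000 nM, which is a limit and not a number. The step therefore shows that this position responds to the change, but it gives only a floor and leaves the true size of the gap unfixed: the limit of > 100000 nM in this assay, at which 2 of the 4 values shown sit.

The compounds shown carry only hydroxy or acetoxy on this oxygen, so it stays open what a longer acyl chain such as butanoyl, or an acyl group bearing an amine or a carboxylic acid, would do in the same place. Also open, on these data alone, is whether acetyl in place of hydrogen on the hydroxy that remains on the shared core of compound 4 would give a further step in the same direction, or none beyond the scatter.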